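Notes on the ester chain: compound 2 to compound 3

The source may hold more compounds than are shown below. What is called first, only, known or untested is meant among the compounds shown, and "the series" means these compounds.

In a physicochemical assay for solubility, read by nephelometry, measured as kinetic solubility (a higher number here means a more soluble compound, a lower number a less soluble compound), compound 1 `CCC/N=C1\S/C(=C\c2ccc(C(=O)O)cc2)C(=O)N1c1ccccc1C` gives 163000 nM as one of two reference points in the series. Compound 2 `CCC/N=C1\S/C(=C\c2ccc(C(=O)OCCCO)cc2)C(=O)N1c1ccccc1O` gives 183000 nM as the other, and this lies within the scatter of compound 1, so the two numbers cannot be ranked.

Compound 3 `CCC/N=C1\S/C(=C\c2ccc(C(=O)OCC3COC(=O)O3)cc2)C(=O)N1c1ccccc1O` has not yet been measured. Its structure departs from compound 2 at the end of the ester chain: 2-oxo-1,3-dioxolan-4-yl in place of 2-hydroxyethyl on a saturated chain carbon bound to an oxygen next to a carbonyl group with 2-oxo-1,3-dioxolan-4-yl in place of 2-hydroxyethyl on a saturated chain carbon bound to an oxygen next to a carbonyl group.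

Among the compounds with values here, no measured pair shows this change, so the expectation rests on the structural change alone and carries a wide margin. A moderate downward step in this assay is expected, although a result within the scatter of compound 2 would not be surprising. The estimated size of the move is a 1.7-fold lower number from compound 2 to compound 3 (0.22 log units; within the scatter) on present information. For compound 3 the estimated value is 110000 nM with an expected range from 40000 nM to 200000 nM in the coming measurement.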

Compound 3, solubility: 79000 nM
Estimate against measurement, compound 3: 1.4-fold (0.14 log units) above; the range from low to high includes it.
By their numbers in this assay, from the lowest: compound 3; then compounds 1 and 2 (each within the scatter of the next).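

Within the data shown here, the end of the ester chain is the first place where this assay gives a step that can be read: a 2.3-fold lower number from compound 2 to compound 3 (0.36 log units; beyond the scatter) accompanies 2-oxo-1,3-dioxolan-4-yl in place of 2-hydroxyethyl on a saturated chain carbon bound to an oxygen next to a carbonyl group. Among these compounds, this single change swaps a group with no ring, 1 hydrogen-bond donor and 1 hydrogen-bond acceptor for one with a five-membered non-aromatic ring, 0 hydrogen-bond donors and 3 hydrogen-bond acceptors, and the one step cannot separate these differences from one another. Nothing at hand accounts for the step.

The compounds shown leave open whether the ring or the loss of the hydroxy group goes with the lower number, a question that an open-chain group such as 2-methoxyethyl at the same place could address. They also leave open how an amine at the end of the ester chain would read in this assay, and whether the step would keep its size on another core.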